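Ester variation at the hydroxyethyl side chain: cytotoxicity notes

A few compounds are considered here, and "the series" means these few. Any claim that something is new, unique, unknown or untested is made for them only; others in the source may bear on it.

Measured compounds:
- Compound 1 `O=c1[nH]c2ccc(Cl)cc2c(-c2ccccc2Cl)c1CCO`: 380000 nM
- Compound 2 `O=C(CCC1CCCCC1)OCCc1c(-c2ccccc2Cl)c2cc(Cl)ccc2[nH]c1=O`: 160000 nM

Going by the values given here, in an ADME assay on HepG2 2.2.15 cells (Homo sapiens) for cytotoxicity (a lower number here means that less compound is tolerated, a higher number that more compound is tolerated), compound 2 gives 160000 nM, the lowest of the two numbers so far; its nearest neighbour is compound 1 with 380000 nM. Among the compounds with values here, the only measured step is a 2.4-fold lower number from compound 1 to compound 2 (0.38 log units; beyond the scatter), a modest step beyond the scatter.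

Compound 3 `COc1ccc(/C=C/C(=O)OCCc2c(-c3ccccc3Cl)c3cc(Cl)ccc3[nH]c2=O)cc1` is not yet measured. It differs from compound 2 as follows: 2-(4-methoxyphenyl)ethenyl in place of 2-cyclohexylethyl on a carbonyl carbon. The ester is retained; only the acyl part changes. Within the data shown here, the single step that bears on this position, a 2.4-fold lower number from compound 1 to compound 2 (0.38 log units; beyond the scatter), concerns the introduction of the ester itself and not the exchange of one acyl group for another, so it offers no direct guide to the present change. With nothing in the measured compounds pointing in either direction, no step beyond the scatter is expected; compound 3 is estimated at 160000 nM, with a range of 60000 nM to 400000 nM, meaning an expected step of no change at the digits printed from compound 2 to compound 3 (within the scatter) in this assay.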

Compound 3, half-maximal cytotoxic concentration: > 1200000 nM
Compound 3 was reported as a limit; the forecaster's own chance of this, stated with the estimate: 15%; middle value at least 7.5-fold (0.87 log units) away from the limit.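

In this assay, putting 2-(4-methoxyphenyl)ethenyl in place of 2-cyclohexylethyl on the carbonyl carbon gives an at least 7.5-fold higher number from compound 2 to compound 3 (0.87 log units; beyond the scatter), so the acyl part itself moves this read-out and the ester is not interchangeable at this position. The lower number of compound 2 therefore cannot be taken as a feature of every ester of the hydroxyethyl side chain, a distinction that a 2.4-fold lower number from compound 1 to compound 2 (0.38 log units; beyond the scatter) alone could not make. Compound 3 gives > 1200000 nM, which is a limit of the assay and not a number, so the step has a lower bound only and its full size stays unknown: the limit of > 1200000 nM in this assay, at which 1 of the 3 values shown sits.

The change swaps a non-aromatic ring for an aromatic one and also brings in a double bond and a methoxy group, so the compounds shown do not tell which of these parts goes with the step. Acyl groups such as 2-phenylethyl, 2-phenylethenyl or 2-(4-methoxyphenyl)ethyl on the same carbonyl carbon would separate these parts, and an acyl chain carrying an amine or a carboxylic acid remains an open case.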